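The source may hold more compounds than are shown below. What is called first, only, known or untested is meant among the compounds shown, and "the series" means these compounds.

Values in a functional assay on LoVo cells (Homo sapiens) for cytotoxicity, read by MTT assay, with a stated time of 72 h; a lower number here means a stronger inhibitor, a higher number a weaker inhibitor:
- compound 1 `O=C1CC(c2c(-c3ccc[nH]3)[nH]c3ccccc23)C(=O)N1` gives 8000 nM
- compound 2 `COc1ccc2[nH]c3c4cn[nH]c4c4c(c3c2c1)C(=O)NC4=O` gives 42000 nM
- compound 3 `Cc1ccc2[nH]c3c4cn[nH]c4c4c(c3c2c1)C(=O)NC4=O` gives 5000 nM

Compound 3 lies within the usual scatter of compound 1, and both numbers sit well under that of compound 2. Compound 4 `O=C1NC(=O)c2c1c1[nH]ncc1c1[nH]c3ccccc3c21` differs from compound 3 by hydrogen in place of methyl on an aromatic carbon in one change: hydrogen in place of methyl on an aromatic carbon. Going by the values given here, the only measured step at this carbon, methyl in place of methoxy, is an 8.4-fold lower number from compound 2 to compound 3 (0.92 log units; beyond the scatter) and lies beyond the scatter. Among the compounds with values here, no measured step removes the methyl, so that step gives no clear direction here. A small change is therefore expected, a 1.2-fold higher number from compound 3 to compound 4 (0.08 log units; within the scatter) as estimated, within the scatter. Compound 4 is estimated at 6000 nM in this assay, with an expected range from 2000 nM to 18000 nM for now.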

Compound 4, half-maximal inhibitory concentration: 44000 nM
Estimate against measurement, compound 4: 7.3-fold (0.87 log units) below; the whole stated range lies below it.
By their numbers in this assay, from the lowest: compounds 3 and 1 (each within the scatter of the next); then compounds 2 and 4 (each within the scatter of the next).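

In this assay, replacing the methyl with hydrogen gives an 8.8-fold higher number from compound 3 to compound 4 (0.94 log units; beyond the scatter), so this carbon does respond to a small change. Replacing the methoxy with hydrogen gives a 1.0-fold higher number from compound 2 to compound 4 (0.02 log units; within the scatter), which leaves hydrogen and methoxy indistinguishable here. Among these three groups, then, the methyl alone stands apart, and the earlier step from methoxy to methyl reflects something particular to the methyl rather than a penalty carried by the methoxy.

Nothing available explains this difference. On these data alone, whether an ethyl group, a chlorine atom or an amine on this carbon would match the methyl or the hydrogen remains open.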